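The compounds below may be only part of what the source reports. "The series", "measured", "known", "first", "only" and "open" are said of these compounds alone.

For the measured compounds named here, the three compounds measured so far share one core and differ in the group on the saturated chain carbon bound to the carbonyl carbon, and in the substitution of the core itself. Compound 1 `C[C@@H]1CN(c2sc(C(F)(F)F)nc2-c2nc3ccccc3[nH]2)CCN1C(=O)CN1CCC(F)(F)CC1` carries a 4,4-difluoropiperidin-1-yl group there and shows, in a functional assay on Venous blood for antagonist activity at C-X-C chemokine receptor type 3 (Homo sapiens), read by flow cytometry, with a stated time of 30 min, in the presence of a further agent that is not named here (a higher number here means a weaker inhibitor, a lower number a stronger inhibitor), a value of 2430 nM. Compound 2 `Cc1nc(C)n(CC(=O)N2CCN(c3sc(C(F)(F)F)nc3-c3nc4ccc(C(C)(C)O)c(F)c4[nH]3)C[C@H]2C)n1` gives 628 nM in this assay, and compound 3 `Cc1nc(C)n(CC(=O)N2CCN(c3sc(C(F)(F)F)nc3-c3nc4ccc(OC5COC5)cc4[nH]3)C[C@H]2C)n1` gives 1480 nM. Compound 1 thus has the highest number of the three; its gap to compound 3 is within the scatter, while its gap to compound 2 lies beyond it.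

Compound 4 `C[C@@H]1CN(c2sc(C(F)(F)F)nc2-c2nc3ccccc3[nH]2)CCN1C(=O)Cn1cc(C2CCN(C)CC2)cn1` keeps the core of compound 1 unchanged and alters only the chain group: 4-(1-methylpiperidin-4-yl)-1H-pyrazol-1-yl in place of 4,4-difluoropiperidin-1-yl on a saturated chain carbon bound to a carbonyl carbon. Going by the values given here, no pair of measured compounds shows this change on its own, so its effect is not known from the data; the closest information is that compounds 2 and 3, with a different group in the same place, do not give higher numbers than compound 1. The step expected from this change is a 1.9-fold lower number from compound 1 to compound 4 (0.27 log units; within the scatter), a modest move toward a lower number that does not clearly pass beyond the scatter. Compound 4 is therefore estimated at 1300 nM, in the range 400 nM to 4000 nM.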

Compound 4, half-maximal inhibitory concentration: 1690 nM
Estimate against measurement, compound 4: 1.3-fold (0.11 log units) below, and the stated range covers the measured number.
By their numbers in this assay, from the lowest: compound 2; then compounds 3, 4 and 1 (each within the scatter of the next).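

The first pair differing only in the group on a saturated chain carbon bound to a carbonyl carbon shows in this assay that the change gives a 1.4-fold lower number from compound 1 to compound 4 (0.16 log units; within the scatter) and so stays within the scatter. On the unchanged core of compound 1, this position therefore accepts 4-(1-methylpiperidin-4-yl)-1H-pyrazol-1-yl in place of 4,4-difluoropiperidin-1-yl without a clear shift in the number, even though the entering group holds more heavy atoms and adds a five-membered aromatic ring. Nothing given here bears on why these two groups read alike.

For the compounds shown here, compound 2 remains the only compound with a number beyond the scatter of compound 1, but it differs from compound 1 in both the chain group and the core substitution, so the share of each cannot be told, and placing its chain group on the unchanged core of compound 1 would separate them. As far as these compounds go, it also remains open whether an open-chain amine such as dimethylamino or a carboxylic acid in this same place would move the number beyond the scatter.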